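Methylcarbamoyl for Cyclopropyl on an Indazole-Type Core

The source may hold more compounds than are shown below. What is called first, only, known or untested is meant among the compounds shown, and "the series" means these compounds.

In an assay on CHO-TREX cells for antagonist activity at transient receptor potential cation channel subfamily A member 1 (Homo sapiens), read by FLIPR and calcium flux, with a stated time of 10 min (a lower number here means a stronger inhibitor, a higher number a weaker inhibitor), compound 2 `FC(F)(F)c1ccccc1-c1cc2cn[nH]c2cc1C1CC1` gives 61 nM, the lowest of the two numbers recorded; compound 1 `Cn1ncc2cc(-c3ccccc3C(F)(F)F)ccc21` gives 7410 nM, a gap beyond the scatter, though the two differ in more than one place. Compound 3 `CNC(=O)c1cc2[nH]ncc2cc1-c1ccccc1C(F)(F)F` is compound 2 with methylcarbamoyl in place of cyclopropyl on an aromatic carbon. For the measured compounds named here, no measured pair isolates this change, so the step is expected to be a clear loss, beyond the scatter, that is a 9.8-fold higher number from compound 2 to compound 3 (0.99 log units; beyond the scatter). For compound 3 in this assay the estimate is 600 nM, with a range from 100 nM to 4000 nM.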

Compound 3, half-maximal inhibitory concentration: > 30000 nM
Compound 3: no number, only a limit (the forecaster's own chance of this, stated with the estimate: 5%); middle value at least 50-fold (1.69 log units) away from the limit.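

On this aromatic carbon, ortho to a large group, methylcarbamoyl in place of cyclopropyl is a large loss in this assay, with an at least 490-fold higher number from compound 2 to compound 3 (2.69 log units; beyond the scatter). For the compounds shown here, this shows that the position does not tolerate every group, which the earlier compounds, differing in more than one place, could not show. Compound 3 has a limit, not a number: the limit of > 30000 nM in this assay, at which 1 of the 3 values shown sits.

As far as these compounds go, how far compound 3 lies past that limit stays open. So does how a plain methyl, a methoxy group or a dimethylcarbamoyl group would read at this position.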